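The compounds below may be only part of what the source reports. "The series", "measured", "known", "first", "only" and "open" are said of these compounds alone.

Measured so far:
compound 1 `C[C@H](c1ccc(C(=O)NCCC(=O)O)cc1)N1C(=O)C(c2cccc(F)c2)=N[C@]12CC[C@@H](C(C)(C)C)CC2`, 490 nM
compound 2 `CC(C)(C)CC[C@H](c1ccc(C(=O)NCc2nn[nH]n2)cc1)N1C(=O)C(c2cc(Cl)cc(Cl)c2)=NC12CCCCC2`, 195 nM

In an assay on CHO cells for displacement of a labelled ligand from Glucagon receptor (Homo sapiens), read by scintillation counting, with a stated time of 60 min (a lower number here means a stronger inhibitor, a higher number a weaker inhibitor), compound 1 gives 490 nM, the higher of the two numbers obtained so far; compound 2 gives 195 nM, and the gap between these two lies beyond the usual scatter. No single change links compound 1 and compound 2, so the pair shows only its two values. Compound 3 `C[C@H](c1ccc(C(=O)NCCC(=O)O)cc1)N1C(=O)C(c2cccc(Cl)c2F)=N[C@]12CC[C@@H](C(C)(C)C)CC2` differs from compound 1 in one place: 3-chloro-2-fluorophenyl in place of 3-fluorophenyl on a carbon with a double bond to nitrogen. Among the measured compounds shown here, no measured step of this kind exists, so the direction is uncertain; a modest move toward a lower number is expected, and the step is estimated as a 2.2-fold lower number from compound 1 to compound 3 (0.35 log units; beyond the scatter). Compound 3 is accordingly expected to give 220 nM in this assay, within 80 nM to 600 nM.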

Compound 3, half-maximal inhibitory concentration: 620 nM
For compound 3 the middle estimate is 2.8-fold (0.45 log units) below the measured one; the measured number lies above the stated range.
By their numbers in this assay, from the lowest: compound 2; then compounds 1 and 3 (each within the scatter of the next).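

In this assay, 3-chloro-2-fluorophenyl in place of 3-fluorophenyl on the carbon with a double bond to nitrogen gives a 1.3-fold higher number from compound 1 to compound 3 (0.10 log units; within the scatter), so this position accepts the larger halogenated phenyl group with compound 1 and compound 3 standing level. Among the compounds shown here, this single pair gives the first direct reading at this position, and no evidence on the cause of the result is at hand. On these data alone, whether a methoxy group, a nitrile or an amine on this phenyl ring would separate from compound 1 remains open. So does whether the same replacement reads alike with a different group on the rest of the core.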